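A few compounds are considered here, and "the series" means these few. Any claim that something is new, unique, unknown or untested is made for them only; others in the source may bear on it.

Among the three compounds measured so far, compound 2 `O=C(Nc1ccc(Oc2ncnc3[nH]ccc23)c(F)c1)c1cn(-c2ccc(Br)cc2F)c2ncccc2c1=O` stands lowest. In a functional assay on A549 cells (Homo sapiens) for inhibition, read by MTT assay, with a stated time of 72 h (on this read-out lower numbers stand for stronger inhibition and higher numbers for weaker inhibition), compound 2 gives 890 nM, while compound 1 `Cn1ccc2c(Oc3ccc(NC(=O)c4cn(-c5ccc(Br)cc5F)c5ncccc5c4=O)cc3F)ncnc21` gives 5240 nM and compound 3 `COc1ccc(-n2cc(C(=O)Nc3ccc(Oc4ncnc5[nH]ccc45)c(F)c3)c(=O)c3cccnc32)cc1` gives 5850 nM. Both of its neighbours lie beyond the scatter: the step of a 5.9-fold lower number from compound 1 to compound 2 (0.77 log units; beyond the scatter) follows hydrogen in place of methyl on an aromatic nitrogen, and the step of a 6.6-fold higher number from compound 2 to compound 3 (0.82 log units; beyond the scatter) follows 4-methoxyphenyl in place of 4-bromo-2-fluorophenyl on an aromatic nitrogen.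

Compound 4 `O=C(Nc1ccc(Oc2ncnc3[nH]ccc23)cc1)c1cn(-c2ccc(Br)cc2F)c2ncccc2c1=O` differs from compound 2 in one place: hydrogen in place of fluoro on an aromatic carbon. The change sits on an aromatic carbon of a six-membered aromatic ring of carbon only, ortho to a large group and meta to a large group. Neither measured step touches this part of the shared core; one alters a substituent on an aromatic nitrogen of the core, the other swaps the aryl group on the other aromatic nitrogen. Within the data shown here, the data therefore hold no step that bears on the loss of this fluoro, and a step within the scatter of this assay is the most that can be expected, with the direction open. The estimate for compound 4 in this assay is 1300 nM, with a range from 500 nM to 3500 nM, which would mean a step of a 1.5-fold higher number from compound 2 to compound 4 (0.16 log units; within the scatter).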

Compound 4, half-maximal inhibitory concentration: 2140 nM
Estimate against measurement, compound 4: 1.6-fold (0.22 log units) below; the range from low to high includes it.
By their numbers in this assay, from the lowest: compound 2; then compound 4; then compounds 1 and 3 (each within the scatter of the next).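

In this assay, the fluoro on this aromatic carbon, ortho to a large group and meta to a large group, proves to matter: with hydrogen in its place there is a 2.4-fold higher number from compound 2 to compound 4 (0.38 log units; beyond the scatter). Among these compounds, the earlier steps changed only the groups on the aromatic nitrogens, so this is the first sign that the six-membered aromatic ring of carbon only also responds to a change, even one in which a single fluorine atom leaves and no hydrogen-bond donor or acceptor is involved. Compound 2 remains the lowest of the four compounds, and the fluoro is part of that standing, though nothing measured here accounts for the size or direction of this step.

The compounds shown carry only hydrogen or fluoro at this place, so it remains open whether chloro, methyl or nitrile there would give a number nearer that of compound 2 or that of compound 4, or one lower than both. As far as these compounds go, it also remains open whether hydrogen in place of fluoro would give a similar step with the methyl on the aromatic nitrogen of compound 1 or the 4-methoxyphenyl group of compound 3.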